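From piperidin-1-yl to (1-phenylethyl)amino: working notes

This account rests on a few compounds, and the source may have more. Where it says the series, first, only, none or still open, it means among the compounds named here.

Values in a functional assay on HL-60 cells (Homo sapiens) for antiproliferative activity, read by MTT assay, with a stated time of 24 h (a higher number here means a weaker inhibitor, a lower number a stronger inhibitor), are as follows:
Compound 1 `CCCCc1oc2ccccc2c1C(=O)c1ccc(OCC(=O)Nc2ccccc2)cc1` gives > 50000 nM (a limit)
Compound 2 `CCCCc1oc2ccccc2c1C(=O)c1ccc(OCC(=O)N[C@@H](C)c2ccccc2)cc1` gives > 50000 nM (a limit)
Compound 3 `CCCCc1oc2ccccc2c1C(=O)c1ccc(OCCCC(=O)N2CCCCC2)cc1` gives 31900 nM

Going by the values given here, compound 3 holds the only actual number in this set. The remaining readings come down to the limit of > 50000 nM in this assay, at which 2 of the 3 values shown sit, and nothing more.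

Compound 4 `CCCCc1oc2ccccc2c1C(=O)c1ccc(OCCCC(=O)N[C@@H](C)c2ccccc2)cc1` is unmeasured. It carries (1-phenylethyl)amino in place of piperidin-1-yl on a carbonyl carbon.

Among the compounds with values here, no measured step matches this exchange. The nearest are (an at least 1.5-fold lower number from compound 1 to compound 3 (0.19 log units; that floor lies within the scatter)) and (an at least 1.5-fold lower number from compound 2 to compound 3 (0.19 log units; that floor lies within the scatter)), and neither floor goes beyond the scatter. The third step (a step that the two limits leave unreadable from compound 1 to compound 2) has no readable size. Compound 4 shares its (1-phenylethyl)carbamoyl group with compound 2 and its chain with compound 3. In this assay the expectation is therefore no step beyond the scatter, and a reading at the limit remains possible.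

The expected step is (a 1.0-fold higher number from compound 3 to compound 4 (0.01 log units; within the scatter)).

For compound 4 the estimated value is 33000 nM with an expected range from 14000 nM to 50000 nM in this series.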

Compound 4, half-maximal inhibitory concentration: > 50000 nM
Compound 4 ended at the assay's limit; the forecaster's own chance of this, stated with the estimate: 30%; at least 1.5-fold (0.18 log units) between middle value and limit.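

Exchanging piperidin-1-yl for (1-phenylethyl)amino on a carbonyl carbon gives, in this assay, an at least 1.5-fold higher number from compound 3 to compound 4 (0.19 log units; that floor lies within the scatter). Compound 4 gives > 50000 nM, which is a limit of the assay and not a number. The chain of compound 3 is therefore not enough on its own for a measured reading, since compound 4 carries that chain and only compound 3, with piperidin-1-yl, gives an actual number, and the series now reads: the limit of > 50000 nM in this assay, at which 3 of the 4 values shown sit.

From the compounds shown here alone, the floor of this step lies within the scatter, so its true size stays open. Also open, going by these compounds, is whether morpholin-4-yl, diethylamino or a free carboxylic acid at this carbonyl carbon would give a measured value in this assay, and so whether piperidin-1-yl is specifically what gives compound 3 its number.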